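A few compounds are considered here, and "the series" means these few. Any claim that something is new, unique, unknown or untested is made for them only; others in the source may bear on it.

Two compounds anchor the series in a functional assay on SMMC-7721 cells (Homo sapiens) for antiproliferative activity, read by MTT assay, with a stated time of 48 h; on this read-out lower numbers stand for stronger inhibition and higher numbers for weaker inhibition: compound 1 (`CC(=O)OC/C1=C/C[C@](C)(CCC=C(C)C)/C=C/[C@@H](OC(=O)C=C(C)C)[C@](C)(O)/C=C/C1=O`) gives 2950 nM, and compound 2 (`CC(=O)O[C@@H]1/C=C/[C@@](C)(CCC=C(C)C)C/C=C(/CO)C(=O)/C=C/[C@@]1(C)O`) gives 9870 nM. Compound 2 therefore holds the higher of the two numbers, meaning the weaker inhibition, and its gap to compound 1 lies beyond the scatter. For the measured compounds named here, compound 3 (`CCCC(=O)O[C@@H]1/C=C/[C@@](C)(CCC=C(C)C)C/C=C(/CO)C(=O)/C=C/[C@@]1(C)O`) has no measurement yet in this assay.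

Compound 3 departs from compound 2 by one change: ethyl in place of hydrogen on a saturated chain carbon bound to a carbonyl carbon. This is ethyl in place of hydrogen on a saturated chain carbon bound to a carbonyl carbon, which reads as acetoxy to (propylcarbonyl)oxy when cut one bond further out. Going by the values given here, no measured pair differs in one place, so this change has no direct precedent. Compound 1 at 2950 nM offers only weak support for a shift towards lower numbers, since it differs from compound 2 in more than one place.

A modest move towards stronger inhibition, probably not clearly beyond the scatter, is expected, with an estimated 1.5-fold lower number from compound 2 to compound 3 (0.18 log units; within the scatter). The estimate for compound 3 is 6500 nM, with an expected range of 2800 nM to 15000 nM.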

Compound 3, half-maximal inhibitory concentration: 7810 nM
The estimate for compound 3 lay 1.2-fold (0.08 log units) below the measured number, within the range that was stated.
By their numbers in this assay, from the lowest: compound 1; then compounds 3 and 2 (each within the scatter of the next).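

In this assay, for the compounds shown here, this is the first step that can be read at a single place: a 1.3-fold lower number from compound 2 to compound 3 (0.10 log units; within the scatter) for ethyl in place of hydrogen on a saturated chain carbon bound to a carbonyl carbon. Compound 2 and compound 3 therefore cannot be told apart on this read-out, and going from acetoxy to (propylcarbonyl)oxy, a change of two added carbons, leaves no mark that repeat measurements could separate from scatter. No independent data are available to explain this result.

A single step cannot show how far this insensitivity extends: a longer chain such as octanoyl, an aromatic ester such as benzoyl, a chain carrying an amine or a carboxylic acid, or the free hydroxyl in place of the ester could each read differently at this place. The compounds shown also leave open whether the same change would read alike on a core carrying other groups, such as the core of compound 1.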